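This account rests on a few compounds, and the source may have more. Where it says the series, first, only, none or still open, it means among the compounds named here.

Series notes. Two compounds of the shared core have numbers in an ADME assay on L929 cells (Mus musculus) for cytotoxicity; on this read-out lower numbers stand for stronger inhibition and higher numbers for weaker inhibition. Compound 1 `Cc1nc(/C=C/[C@@H]2C[C@@H]3O[C@@H]3CCC[C@H](C)[C@H](O)[C@@H](C)C(=O)C(C)(C)[C@@H](O)CC(=O)O2)cs1` gives 0.02 ug/mL; compound 2 `Cc1nc(/C=C(\CO)[C@@H]2C[C@@H]3O[C@@H]3CCC[C@H](C)[C@H](O)[C@@H](C)C(=O)C(C)(C)[C@@H](O)CC(=O)O2)cs1` gives 0.1 ug/mL. For the measured compounds named here, on these two numbers compound 2 stands highest, and the only measured step, a 5.0-fold higher number from compound 1 to compound 2 (0.70 log units; beyond the scatter), runs from compound 1 to compound 2.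

Compound 3 `C/C(=C\c1coc(C)n1)[C@@H]1C[C@@H]2O[C@@H]2CCC[C@H](C)[C@H](O)[C@@H](C)C(=O)C(C)(C)[C@@H](O)CC(=O)O1` is not yet measured. Against compound 2 the change is a group of 9 heavy atoms (7 carbon, 1 nitrogen, 1 oxygen; one five-membered aromatic ring with 2 hetero atoms) in place of a group of 10 heavy atoms (7 carbon, 1 nitrogen, 1 oxygen, 1 sulfur; one five-membered aromatic ring with 2 hetero atoms), on a saturated ring carbon. Going by the values given here, one measured step bears on this, and only in part: it covers the loss of the hydroxy group on the entering side, while the exchange of the aromatic ring has no precedent in this assay. Reversing the direction of that step, a lower number than compound 2 is expected for compound 3, of about the same size, with added uncertainty from the ring exchange; the expected step is a 3.3-fold lower number from compound 2 to compound 3 (0.52 log units; beyond the scatter). Compound 3 is therefore estimated at 0.03 ug/mL, with a range from 0.008 ug/mL to 0.1 ug/mL.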

Compound 3, half-maximal inhibitory concentration: 0.006 ug/mL
Compound 3: middle estimate off by 5.0-fold (0.70 log units), on the high side; measured number outside the range, below it.
By their numbers in this assay, from the lowest: compound 3; then compound 1; then compound 2.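

In this assay, the change on the saturated ring carbon next to the ring oxygen proves able to lower the number well past the level of compound 1, which had been the lowest so far: a 3.3-fold lower number from compound 1 to compound 3 (0.52 log units; beyond the scatter), and, against the hydroxy-bearing group, a 17-fold lower number from compound 2 to compound 3 (1.22 log units; beyond the scatter). Each of these steps changes the five-membered aromatic ring and the rest of the group at once, so the series now shows that this position responds strongly to the whole group, but not which part of it is responsible. Nothing available accounts for the size of either step.

Still open, going by these compounds, is how much of each step belongs to the exchange of sulfur for oxygen in the aromatic ring and how much to the group on the double bond. Also open, on these data alone, is how an amine or a carboxylic acid in place of that hydroxy group would read in this assay.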